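The source may hold more compounds than are shown below. What is called first, only, known or untested is meant among the compounds shown, and "the series" means these compounds.

Measured so far in a functional assay on DU-145 cells (Homo sapiens) for inhibition, read by trypan blue exclusion, with a stated time of 96 h; a lower number here means a stronger inhibitor of growth, a higher number a weaker inhibitor of growth:

- compound 1 `Cc1ccc(S(=O)(=O)/C(=C/c2ccc(C)s2)C(=O)c2ccc(Cl)cc2)cc1`, giving 50000 nM
- compound 2 `Cc1ccc(/C=C(/SCc2ccc(Cl)cc2)C(=O)c2ccc(Cl)cc2)s1`, giving 50000 nM
- compound 3 `Cc1ccc(S(=O)(=O)/C(=C/c2cc(C)ccc2C)C(=O)c2ccc(Cl)cc2)cc1`, giving 1000 nM

Compound 2 stands level with compound 1 at the digits given, within the scatter, and the two together give the highest numbers of the three. How the core of compound 1 differs from the core of compound 2 is not broken down here. Compound 3 carries 2,5-dimethylphenyl in place of 5-methylthiophen-2-yl on a double-bonded chain carbon bound to a double-bonded chain carbon and the step of a 50-fold lower number from compound 1 to compound 3 (1.70 log units; beyond the scatter) is large and beyond the scatter.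

Compound 4 `Cc1ccc(C)c(/C=C(/SCc2ccc(Cl)cc2)C(=O)c2ccc(Cl)cc2)c1` is not yet measured. It carries the same change on the core of compound 2, namely (2,5-dimethylphenyl in place of 5-methylthiophen-2-yl on a double-bonded chain carbon bound to a double-bonded chain carbon), and the place is described in the same words for both pairs. The change has been seen once only, on a different core, so its transfer to compound 2 is uncertain. A step of a 25-fold lower number from compound 2 to compound 4 (1.40 log units; beyond the scatter) in this assay is expected, taken somewhat smaller than a 50-fold lower number from compound 1 to compound 3 (1.70 log units; beyond the scatter) since that step rests on a single pair. Compound 4 is therefore estimated at 2000 nM, with a range from 500 nM to 20000 nM.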

Compound 4, concentration for 50% growth inhibition: 10000 nM
Estimate against measurement, compound 4: 5.0-fold (0.70 log units) below; the range from low to high includes it.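

The change keeps its direction on the second core, giving a 5.0-fold lower number from compound 2 to compound 4 (0.70 log units; beyond the scatter) in this assay. Its size does not carry over from the core of compound 1 to the core of compound 2: the same change on two cores in this assay, a 50-fold lower number (1.70 log units; beyond the scatter) from compound 1 to compound 3 and a 5.0-fold lower number (0.70 log units; beyond the scatter) from compound 2 to compound 4, 10-fold (1.00 log units) apart, beyond the scatter of two such steps. These two pairs show that the direction held on these two cores, but they do not show what in the cores sets the size of the step, and they cannot predict the size on a further core.

Open, on these data alone, is how a phenyl ring carrying an amine or a carboxylic acid would read in place of 2,5-dimethylphenyl on either core. Also open, as far as these compounds go, is whether an unsubstituted phenyl ring would give a step of the same direction, or whether both methyl groups of 2,5-dimethylphenyl are needed for it.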